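A few compounds are considered here, and "the series" means these few. Any claim that something is new, unique, unknown or untested is made for them only; others in the source may bear on it.

Series of enone alcohols examined in a functional assay on SW1573 cells (Homo sapiens) for antiproliferative activity, read by sulforhodamine B assay, with a stated time of 48 h; on this read-out lower numbers stand for stronger inhibition of growth and higher numbers for weaker inhibition of growth. Compound 1 `CCCCCC/C=C/C(=O)CC(O)CCCCCC` gives 25000 nM. Compound 2 `CC(C)(C)/C=C/C(=O)CC(O)C(C)(C)C` gives 26000 nM. Compound 3 `CC(C)CC(O)CC(=O)/C=C\c1ccccc1`, which carries an aromatic ring at the end of the enone, gives 13000 nM. Compound 3 holds the lowest of the three numbers; its nearest neighbour is compound 1 and its furthest is compound 2, yet both gaps fall inside the usual scatter of repeated runs, so the three values show no separation that can be read as an order among them.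

Compound 4 `Cc1ccc(/C=C\C(=O)CC(O)CC(C)C)cc1` has not been measured. It differs from compound 3 by methyl in place of hydrogen on an aromatic carbon. For the measured compounds named here, no step between two measured compounds carries this kind of change, so the expected size of the step rests on the change itself, which adds a single carbon to the aromatic ring. With nothing in the measured set pointing one way or the other, the expected step from compound 3 to compound 4 in this assay is a 1.2-fold lower number from compound 3 to compound 4 (0.07 log units; within the scatter), that is, none beyond the scatter in either direction. Compound 4 is therefore estimated to give 11000 nM, with a range from 5000 nM to 25000 nM.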

Compound 4, concentration for 50% growth inhibition: 12000 nM
Compound 4: the middle estimate sits 1.1-fold (0.04 log units) below what was measured; low and high end bracket the measured number.
By their numbers in this assay, from the lowest: compounds 4, 3, 1 and 2 (each within the scatter of the next, the first and the last beyond it).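

In this assay, methyl in place of hydrogen on an aromatic carbon, para to a large group, gives a 1.1-fold lower number from compound 3 to compound 4 (0.03 log units; within the scatter) and so opens no separation at this position. For the compounds shown here, this is the first step that differs in one place only, since the earlier compounds differ from one another in several places at once and could not isolate any single group; it shows that the six-membered aromatic ring of compound 3 accepts this one added carbon with its growth-inhibition number left inside the scatter. No measured finding is available that bears on this result.

The compounds shown leave open whether a group other than methyl at this same place, such as an amine, a carboxylic acid or a longer alkyl chain, would move the number beyond the scatter. They also leave open whether a methyl elsewhere on the aromatic ring would behave as this one does, and the reading for this position rests on a single pair.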